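A few compounds are considered here, and "the series" means these few. Any claim that something is new, unique, unknown or untested is made for them only; others in the source may bear on it.

Compound 1 `Cc1ccc2oc(-c3ccc(NC(=O)CN4CCN(CCN(C)C)CC4)c(C)c3)nc2c1` and compound 2 `Cc1cc(-c2nc3ccccc3o2)ccc1NC(=O)CN1CCN(CCN(C)C)CC1` differ in one place: hydrogen in place of methyl on an aromatic carbon. In a functional assay on HepG2 cells (Homo sapiens) for cytotoxicity, read by MTT assay, with a stated time of 24 h (on this read-out lower numbers stand for stronger inhibition and higher numbers for weaker inhibition), compound 1 gives 12800 nM, and compound 2 gives 19900 nM, which is the step of a 1.6-fold higher number from compound 1 to compound 2 (0.19 log units; within the scatter). Compound 3 `Cc1cc(-c2nc3ccccc3o2)ccc1NC(=O)CN1CCN(CCCN(C)C)CC1` has the same atoms as compound 1 joined differently; the difference between the two cores is not broken down here. The step of a 9.2-fold lower number from compound 2 to compound 3 (0.96 log units; beyond the scatter) is the larger one, and in this assay compound 3 gives 2160 nM. Compound 4 `CN(C)CCCN1CCN(CC(=O)Nc2ccc(-c3nc4ccccc4o3)cc2)CC1` differs from compound 3 by hydrogen in place of methyl on an aromatic carbon, the same kind of change as from compound 1 to compound 2, but the place differs: here it is on a six-membered aromatic ring of carbon only, ortho to a large group and meta to a 1,3-benzoxazol-2-yl group, not on a ring within a fused system. Because a 1.6-fold higher number from compound 1 to compound 2 (0.19 log units; within the scatter) lay within the scatter, the expected step is a 1.4-fold higher number from compound 3 to compound 4 (0.14 log units; within the scatter). Compound 4 is therefore estimated at 3000 nM, between 1500 nM and 6500 nM.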

Compound 4, half-maximal inhibitory concentration: 9500 nM
Estimate against measurement, compound 4: 3.2-fold (0.50 log units) below, and the stated range ends below it.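

Replacing methyl with hydrogen on an aromatic carbon gives, in this assay, a 4.4-fold higher number from compound 3 to compound 4 (0.64 log units; beyond the scatter), so the methyl matters on this core. The same kind of change therefore cannot be carried from one core to the other at a fixed size: the same change on two cores in this assay, a 1.6-fold higher number (0.19 log units; within the scatter) from compound 1 to compound 2 and a 4.4-fold higher number (0.64 log units; beyond the scatter) from compound 3 to compound 4, 2.8-fold (0.45 log units) apart, beyond the scatter of two such steps. These two pairs do not show what sets the size, since they differ both in where the methyl sits and in the chain carrying the dimethylamino group, and two pairs cannot separate those differences.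

Still open, on these data alone, is what an ethyl group or a chlorine atom would give on the ring carbon that holds the methyl in compound 3. As far as these compounds go, a longer chain ending in the dimethylamino group, with or without that methyl, also remains open.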